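A Second Methoxy Group on the Shared Core

A few compounds are considered here, and "the series" means these few. Any claim that something is new, unique, unknown or untested is made for them only; others in the source may bear on it.

Three compounds have so far been measured in an assay for inhibition of Retinaldehyde dehydrogenase 3 (Homo sapiens), with a stated time of 5 min; on this read-out higher numbers stand for weaker inhibition and lower numbers for stronger inhibition:

compound 1 `CSc1ccc(-c2ccc3nc(-c4ccccc4)cn3c2)cc1`: 27100 nM
compound 2 `COc1ccc(-c2ccc3nc(-c4ccccc4)cn3c2)cc1`: 17800 nM
compound 3 `COC(=O)c1ccc(-c2ccc3nc(-c4ccccc4)cn3c2)cc1`: 27400 nM

Compound 2 gives the smallest of the three numbers, yet every step separating it from the others is within the scatter: a 1.5-fold lower number from compound 1 to compound 2 (0.18 log units; within the scatter) and a 1.5-fold higher number from compound 2 to compound 3 (0.19 log units; within the scatter), with a 1.0-fold higher number from compound 1 to compound 3 (0.00 log units; within the scatter) between the other two. All three measured steps exchange the group on one phenyl ring, while the other phenyl ring of the shared core stays unchanged.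

Going by the values given here, compound 4 `COc1ccc(-c2ccc3nc(-c4ccc(OC)cc4)cn3c2)cc1` differs from compound 2 by methoxy in place of hydrogen on an aromatic carbon, that is, on the phenyl ring that none of the measured steps has touched. Among the compounds with values here, no measured step therefore bears directly on this change; the only guidance is that every exchange recorded on this core so far stayed within the scatter. On that basis the step from compound 2 to compound 4 is expected to be a 1.0-fold higher number from compound 2 to compound 4 (0.00 log units; within the scatter), nothing beyond the scatter. The estimate for compound 4 in this assay is 18000 nM, with a range from 6000 nM to 55000 nM.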

Compound 4, half-maximal inhibitory concentration: 11400 nM
Beside the measured number, compound 4's estimate is 1.6-fold (0.20 log units) above it, and the stated range covers the measured number.
By their numbers in this assay, from the lowest: compounds 4, 2, 1 and 3 (each within the scatter of the next, the first and the last beyond it).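

Going by these compounds alone, the phenyl ring left untouched by the earlier steps now has a reading of its own: in this assay, methoxy in place of hydrogen on an aromatic carbon, para to a large group, gives a 1.6-fold lower number from compound 2 to compound 4 (0.19 log units; within the scatter) and so stays within the scatter. Substitution on this ring therefore behaves so far like the three exchanges on the other phenyl ring, and this single step shows no separable effect of phenyl to 4-methoxyphenyl. No supporting measurement is available to explain the size of this step.

The compounds shown leave open whether another group on this ring, such as an amine, a carboxylic acid or a longer chain, would move the number beyond the scatter. They also leave open whether methoxy here would give a similar step with methylsulfanyl or methoxycarbonyl on the other phenyl ring.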